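A few compounds are considered here, and "the series" means these few. Any claim that something is new, unique, unknown or untested is made for them only; others in the source may bear on it.

Measured so far in a physicochemical assay for solubility, at pH 6.8; on this read-out lower numbers stand for lower solubility and higher numbers for higher solubility:

compound 1, `CN1CCc2nc(C(=O)NC3CCN(C(=O)OC(C)(C)C)CC3NC(=O)c3cc4cc(Cl)ccc4[nH]3)sc2C1`, a limit: < 1 ug/mL
compound 2, `CN1CCc2nc(C(=O)NC3CCNCC3NC(=O)c3cc4cc(Cl)ccc4[nH]3)sc2C1`: 830 ug/mL
compound 3, `CN1CCc2nc(C(=O)NC3CCN(S(C)(=O)=O)CC3NC(=O)c3cc4cc(Cl)ccc4[nH]3)sc2C1`: 70 ug/mL

In this assay compound 1 gives only a limit, not a number, at the limit of < 1 ug/mL in this assay, at which 1 of the 3 values shown sits. Compound 2 gives 830 ug/mL. Compound 3 gives 70 ug/mL and so stands lowest of the two actual numbers: a 12-fold lower number from compound 2 to compound 3 (1.07 log units; beyond the scatter).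

Compound 4, `CCOC(=O)N1CCC(NC(=O)c2nc3c(s2)CN(C)CC3)C(NC(=O)c2cc3cc(Cl)ccc3[nH]2)C1`, differs from compound 3 in one place: ethoxycarbonyl in place of methylsulfonyl on an amine nitrogen in a ring. Among the measured compounds shown here, no measured step exchanges exactly these two groups, so the steps that bear on it are the ones that alter the same ring nitrogen: an at least 830-fold higher number from compound 1 to compound 2 (2.91 log units; beyond the scatter), an at least 70-fold higher number from compound 1 to compound 3 (1.84 log units; beyond the scatter) and a 12-fold lower number from compound 2 to compound 3 (1.07 log units; beyond the scatter). Both groups that replaced tert-butoxycarbonyl raised the number, and the ethoxycarbonyl that enters compound 4 is, like tert-butoxycarbonyl, a carbamate. Compound 4 is therefore expected to sit below compound 3, with a 7.0-fold lower number from compound 3 to compound 4 (0.85 log units; beyond the scatter), though not as far down as compound 1. The estimate for compound 4 in this assay is 10 ug/mL, expected to lie between 2 ug/mL and 50 ug/mL.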

Compound 4, solubility: 37 ug/mL
The estimate for compound 4 lay 3.7-fold (0.57 log units) below the measured number; the measured number falls inside the stated range.
By their numbers in this assay, from the lowest: compounds 4 and 3 (each within the scatter of the next); then compound 2. At a limit, below all of these: compound 1.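

In this assay, ethoxycarbonyl in place of methylsulfonyl on the ring amine nitrogen gives a 1.9-fold lower number from compound 3 to compound 4 (0.28 log units; within the scatter), so this exchange does not separate the two groups, although one is a carbamate and the other is not. Compound 2, with hydrogen on that nitrogen, remains apart from the capped compounds, as the step to the second carbamate shows: a 22-fold lower number from compound 2 to compound 4 (1.35 log units; beyond the scatter). Within the carbamates, ethyl in place of tert-butyl on an oxygen next to a carbonyl group gives an at least 37-fold higher number from compound 1 to compound 4 (1.56 log units; beyond the scatter), which shows that a carbamate on this nitrogen need not sit as low as compound 1, and the size of this step is only a bound, as compound 1 gives a limit and not a number: the limit of < 1 ug/mL in this assay, at which 1 of the 4 values shown sits.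

The compounds shown leave open whether a small alkyl group such as methyl on the same nitrogen, which would keep an amine there, would stay near compound 2. From the compounds shown here alone, it also remains open where an acetyl group, a carbamate with a longer chain such as butoxycarbonyl, or a group carrying a carboxylic acid would fall relative to compound 3 and compound 4.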